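Working notes: aryl exchange from compound 2 to compound 4

The source may report more compounds than this note shows. Statements on the series, on what has been measured and on what is new or still open speak of the compounds shown alone.

Measured half-maximal inhibitory concentrations:
- compound 1 `O=c1ccc2cc(OCc3cc(-c4cccc(Cl)c4)no3)ccc2o1` gives 50600 nM
- compound 2 `COc1ccc(-n2cc(COc3ccc4oc(=O)ccc4c3)nn2)cc1` gives 46400 nM
- compound 3 `CC(=O)Nc1ccc(-n2cc(COc3ccc4oc(=O)ccc4c3)nn2)cc1` gives 40400 nM

In a functional assay on HL-60 cells (Homo sapiens) for cytotoxicity, read by MTT assay, with a stated time of 48 h (on this read-out higher numbers stand for weaker inhibition and lower numbers for stronger inhibition), compound 2 stands second highest of the three numbers, within the scatter of both neighbours. Compound 4 `O=c1ccc2cc(OCc3cn(-c4ccc(Cl)c(Cl)c4)nn3)ccc2o1` carries 3,4-dichlorophenyl in place of 4-methoxyphenyl on an aromatic nitrogen. For the measured compounds named here, one measured step bears on this group: acetamido in place of methoxy gives a 1.1-fold lower number from compound 2 to compound 3 (0.06 log units; within the scatter) and stays within the scatter. Going by the values given here, no measured compound carries 3,4-dichlorophenyl, so this guide is weak. No shift beyond the scatter is therefore expected in this assay, and the estimated change is a 1.2-fold lower number from compound 2 to compound 4 (0.09 log units; within the scatter) in size. Compound 4 is expected at 38000 nM (estimated range 15000 nM to 80000 nM).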

Compound 4, half-maximal inhibitory concentration: 47800 nM
The estimate for compound 4 lay 1.3-fold (0.10 log units) below the measured number; the measured number falls inside the stated range.
By their numbers in this assay, from the lowest: compounds 3, 2, 4 and 1 (each within the scatter of the next).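

In this assay, 3,4-dichlorophenyl in place of 4-methoxyphenyl on an aromatic nitrogen gives a 1.0-fold higher number from compound 2 to compound 4 (0.01 log units; within the scatter) and so leaves the number unmoved. For the compounds shown here, at this place, an aryl group with two chlorine and no hydrogen-bond acceptor therefore reads the same as one with a methoxy oxygen, extending the flat picture beyond the single acetamido step. No measurement at hand offers a reason for this result. Still open, as far as these compounds go, is whether a carboxylic acid or an aminomethyl group on this aryl ring, or a longer chain replacing the ring, would move the number beyond the scatter.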